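A few compounds are considered here, and "the series" means these few. Any claim that something is new, unique, unknown or untested is made for them only; others in the source may bear on it.

Working notes on a set of nitrate esters sharing one core. Compound 1 `Cc1cc(OC(=O)c2ccc(CC(CO[N+](=O)[O-])O[N+](=O)[O-])cc2)n(-c2ccccc2)n1` and compound 2 `Cc1cc(OC(=O)c2ccc(CCCO[N+](=O)[O-])cc2)n(-c2ccccc2)n1` share one core; compound 3 `Cc1cc(OC(=O)c2ccc(OCC(CO[N+](=O)[O-])O[N+](=O)[O-])cc2)n(-c2ccccc2)n1` and compound 4 `Cc1cc(OC(=O)c2ccc(OCCCO[N+](=O)[O-])cc2)n(-c2ccccc2)n1` share another, and the difference between the two cores is not broken down here. In an ADME assay on a cell-free system (serum, Homo sapiens) for metabolic stability, read by HPLC, tested at 250 uM (a higher number here means that the compound lasts longer, a lower number that the compound disappears faster), compound 1 gives 0.118 h. Compound 2 gives 0.0667 h in this assay; the change is hydrogen in place of nitrooxy on a saturated chain carbon bound to two saturated chain carbons, and the step is a 1.8-fold lower number from compound 1 to compound 2 (0.25 log units; within the scatter). Compound 3 gives 0.13 h in this assay; compound 3 and compound 1 lie within the scatter of each other, as do compound 3 and compound 2. Compound 4 has not yet been measured. It differs from compound 3 by hydrogen in place of nitrooxy on a saturated chain carbon bound to two saturated chain carbons, the same change as from compound 1 to compound 2, at the same kind of place. For this assay the step is expected to be a 1.7-fold lower number from compound 3 to compound 4 (0.24 log units; within the scatter), because the matching change gave a 1.8-fold lower number from compound 1 to compound 2 (0.25 log units; within the scatter), a step within the scatter. On that basis compound 4 is estimated at 0.075 h in this assay, with an expected range of 0.04 h to 0.15 h.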

Compound 4, half-life in the serum assay: 0.0833 h
Estimate against measurement, compound 4: 1.1-fold (0.05 log units) below, within the range that was stated.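

In the serum assay hydrogen in place of nitrooxy on a saturated chain carbon bound to two saturated chain carbons behaves alike on both cores, with no detectable difference between the steps: the same change on two cores in the serum assay, a 1.8-fold lower number (0.25 log units; within the scatter) from compound 1 to compound 2 and a 1.6-fold lower number (0.19 log units; within the scatter) from compound 3 to compound 4, 1.1-fold (0.05 log units) apart, within the scatter of two such steps. Each step is small, however: a 1.6-fold lower number from compound 3 to compound 4 (0.19 log units; within the scatter) is no larger than the scatter, and neither is a 1.2-fold higher number from compound 2 to compound 4 (0.10 log units; within the scatter) (the swap of 3-(nitrooxy)propyl for 3-(nitrooxy)propoxy on an aromatic carbon). The agreement shows transfer only in the sense that neither core gives a real shift, not that the change has a shared effect of a definite size. In a physicochemical assay for metabolic stability, read by HPLC (on this read-out lower numbers stand for a shorter-lived compound and higher numbers for a longer-lived compound), compound 3 gives 25 h and compound 4 gives 35 h and a 1.4-fold higher number from compound 3 to compound 4 (0.15 log units; within the scatter) is likewise within the scatter, and this pair alone cannot show transfer to another core there.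

From the compounds shown here alone, whether the same change would stay this small on a core outside these two remains open. Also open, going by these compounds, is whether an amine or a carboxylic acid in place of nitrooxy, or a longer chain than 3-(nitrooxy)propyl, would give a step beyond the scatter in the serum assay.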